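This account rests on a few compounds, and the source may have more. Where it says the series, first, only, none or still open, it means among the compounds named here.

Of the compounds shown here, two have been tested so far. Compound 1 `O=c1cc(NC2CCCCC2)cc(/C=C/c2ccccc2)o1` carries a cyclohexyl group on the amine and a styryl group on the other side of the shared core, and in a functional assay on DU-145 cells (Homo sapiens) for cytotoxicity, read by MTT assay, with a stated time of 72 h (on this read-out lower numbers stand for an effect already at smaller amounts and higher numbers for an effect only at larger amounts of compound), compound 1 gives 1.23 uM. Compound 2 `O=c1cc(Nc2ccccc2)cc(-c2ccccc2)o1` has a phenyl group in both of those places instead, and in this assay compound 2 gives 0.098 uM. Compound 2 therefore stands at the lowest number of the two, and its gap to compound 1 lies beyond the usual scatter of this kind of measurement.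

Compound 3 `O=c1cc(Nc2ccc(Br)cc2)cc(-c2ccccc2)o1` is built from compound 2 by a single change: bromo in place of hydrogen on an aromatic carbon, so that the phenyl on the amine becomes a 4-bromophenyl. Among the compounds with values here, no measured pair shows what such an exchange does, so nothing here points in one direction or the other. On that basis the expected step of a 1.2-fold higher number from compound 2 to compound 3 (0.09 log units; within the scatter) is small and stays within the scatter. Compound 3 is accordingly estimated to give 0.12 uM in this assay, with a likely range from 0.04 uM to 0.4 uM.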

Compound 3, concentration for half-maximal effect: 0.34 uM
Compound 3: middle estimate off by 2.8-fold (0.45 log units), on the low side; low and high end bracket the measured number.
By their numbers in this assay, from the lowest: compound 2; then compound 3; then compound 1.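

Within the data shown here, this is the first pair that differs in one place only, so the effect of a single change can now be read directly. In this assay, exchanging hydrogen for bromo on an aromatic carbon, para to a large group, gives a 3.5-fold higher number from compound 2 to compound 3 (0.54 log units; beyond the scatter) and turns the phenyl on the amine into a 4-bromophenyl. The step is modest but lies beyond the scatter, which shows that this position is not indifferent to substitution: with the bromo group present, the effect appears only at a larger amount of compound. Nothing among the data shown accounts for this rise.

Going by these compounds, one substituent at one position cannot show whether the rise belongs to bromo alone, so it remains open how a fluoro, a methoxy or an amine group would behave in the same place, or how bromo would behave elsewhere on this ring or on the other phenyl. Compound 1 and compound 2 also differ in two places, which leaves the separate contributions of the cyclohexyl and styryl groups unresolved.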